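Methyl for Methoxy on the Fused Ring of Compound 2

This account rests on a few compounds, and the source may have more. Where it says the series, first, only, none or still open, it means among the compounds named here.

For the measured compounds named here, compound 2 `COc1ccc2ncc(S(=O)(=O)c3cccc(Cl)c3)c(N3CCC(C)CC3)c2c1` stands lowest of the two numbers known in an assay on isolated protein for displacement of a labelled ligand from metabotropic glutamate receptor 5 (Homo sapiens), with a stated time of 60 min, tested at 1 uM; a higher number here means more inhibition at the concentration tested (going by the name of the read-out), a lower number less inhibition: compound 2 gives -3%, whereas compound 1 `CC1CCN(c2c(S(=O)(=O)c3cccc(Cl)c3)cnc3ccc(Cl)cc23)CC1` gives 92%. Going by the values given here, the only step known, a number 95 percentage points lower from compound 1 to compound 2 (beyond the scatter), bears on the present change only indirectly, since compound 3 `Cc1ccc2ncc(S(=O)(=O)c3cccc(Cl)c3)c(N3CCC(C)CC3)c2c1` differs from compound 2 by methyl in place of methoxy on an aromatic carbon rather than by a return to chloro. With no direct comparison available, a partial recovery is expected, as a number 48 percentage points higher from compound 2 to compound 3 (beyond the scatter), with wide uncertainty. Compound 3 is therefore estimated at 45%, between 5% and 88%.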

Compound 3, a percentage reported as inhibition, at one concentration (the size of the read-out at that concentration, not a potency): 91%
For compound 3 the middle estimate is 46 percentage points below the measured one; the whole stated range lies below it.
By their numbers in this assay, from the lowest: compound 2; then compounds 3 and 1 (each within the scatter of the next).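

Methyl in place of methoxy on this aromatic carbon brings the read-out in this assay back (a number 94 percentage points higher from compound 2 to compound 3 (beyond the scatter)), so the earlier loss goes with methoxy here and does not require chloro to be absent. Methyl and chloro at this place cannot be told apart (a number 1 percentage points lower from compound 1 to compound 3 (within the scatter)). Nothing available here explains why methoxy behaves so differently from methyl.

Still open, as far as these compounds go, is whether ethyl, fluoro or an amine at this place would behave like methyl or like methoxy. Also open, from the compounds shown here alone, is whether ethoxy would share the result of methoxy.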